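Cyclobutyloxy in place of trifluoromethoxy on the aryl ether

A few compounds are considered here, and "the series" means these few. Any claim that something is new, unique, unknown or untested is made for them only; others in the source may bear on it.

Compound 2 `Fc1ccc(OC(F)(F)F)cc1-c1ccc2c(c1)CC[C@H](CCc1nnn[nH]1)O2` stands at the ceiling of a functional assay on HEK293 cells for agonist activity at Free fatty acid receptor 1 (Homo sapiens), read by HTRF and inositol phosphate accumulation, with a stated time of 60 min (a higher number here means that more compound is needed for the effect, a lower number that less compound is needed), where it gives > 10000 nM; this is a limit of the assay and not a number. Compound 1 `COc1cc(OC(F)(F)F)cc(-c2ccc3c(c2)CC[C@H](CCc2nnn[nH]2)O3)c1F` likewise sits at the limit, giving > 10000 nM. The step that the two limits leave unreadable from compound 1 to compound 2 is accordingly unreadable. Compound 3 `O=C(O)CC[C@H]1CCc2cc(-c3cc(OC(F)(F)F)ccc3F)ccc2O1` gives 2100 nM in this assay, and the step of an at least 4.7-fold lower number from compound 2 to compound 3 (0.67 log units; beyond the scatter) is the only one with a readable size; it concerns the acidic end of the chain, not the aryl ether. The two limits rest on (the limit of > 10000 nM in this assay, at which 2 of the 3 values shown sit).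

Compound 4 `Fc1ccc(OC2CCC2)cc1-c1ccc2c(c1)CC[C@H](CCc1nnn[nH]1)O2` differs from compound 2 by cyclobutyl in place of trifluoromethyl on an oxygen on an aromatic ring. Among the compounds with values here, no measured step touches the substituent on this oxygen, so neither measured step bears on it, and no size or direction can be expected from the present data beyond the scatter. Compound 4 is therefore estimated at 12000 nM, with a range from 3000 nM to 50000 nM, most probably again reported as a limit. The expected step that the limit leaves unreadable from compound 2 to compound 4 is thus one that cannot be read against a limit.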

Compound 4, half-maximal effective concentration: > 10000 nM
Compound 4: a limit, no number (the forecaster's own chance of this, stated with the estimate: 60%); the middle value does not contradict the limit.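

Compound 4 gives > 10000 nM in this assay, which is a limit of the assay and not a number. Compound 2 also stands at a limit, so the step between these two compounds cannot be read: the limit of > 10000 nM in this assay, at which 3 of the 4 values shown sit.

The compounds shown leave open how cyclobutyloxy compares with trifluoromethoxy on the aryl ether in this assay.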